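This account rests on a few compounds, and the source may have more. Where it says the series, first, only, none or still open, it means among the compounds named here.

Among the compounds with values here, in a physicochemical assay for lipophilicity, read by HPLC, at pH 7.4 (on this read-out lower numbers stand for lower lipophilicity and higher numbers for higher lipophilicity), compound 2 (`Cc1ccccc1N1C(=O)/C(=C/c2ccc(O)c(Cl)c2)S/C1=N\C1COC1`) gives 2.6, the only true number available so far. Compound 1 (`CCC/N=C1\S/C(=C\c2ccc(O)c(Cl)c2)C(=O)N1C(C)C`) gives > 4.3, which is a limit of the assay and not a number. Compound 3 (`CCC/N=C1\S/C(=C\c2ccc(O)c(Cl)c2)C(=O)N1c1ccccc1C`) has not yet been measured. It differs from compound 2 by having propyl in place of oxetan-3-yl on a double-bonded nitrogen. Within the data shown here, no measured pair shows this change on its own, so the only guide is compound 1, which also carries propyl on a double-bonded nitrogen but differs elsewhere, and which reads > 4.3, again a limit. An upward move in this assay is therefore expected, with an estimated size of a number 1.80 log units higher from compound 2 to compound 3 (beyond the scatter), well beyond the usual scatter. The expected value for compound 3 is 4.4, within an estimated range of 3.8 to 5.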

Compound 3, distribution coefficient: 3.8
Estimate against measurement, compound 3: 0.60 log units above, within the range that was stated.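

Compound 3 gives the swap of oxetan-3-yl for propyl on a double-bonded nitrogen a measured size of its own in this assay, as the change produces a number 1.20 log units higher from compound 2 to compound 3 (beyond the scatter). It also shows that the group on the amide-type nitrogen in a ring matters on this read-out, since 2-methylphenyl in place of isopropyl gives a number at least 0.50 log units lower from compound 1 to compound 3 (beyond the scatter). That second step has only one firm end, as compound 1 stands at a limit of the assay and not at a number: the limit of > 4.3 in this assay, at which 1 of the 3 values shown sits.

On these data alone, each change is seen only once, so it remains unknown whether the propyl step would keep its size with isopropyl on the amide-type nitrogen in a ring. Where a longer chain or an amine on the double-bonded nitrogen would fall also remains open.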